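Compound 3 to compound 4: methoxy in place of chloro

The compounds below may be only part of what the source reports. "The series", "measured", "known", "first", "only" and "open" are said of these compounds alone.

- compound 1 `CCN1C(=O)C(=O)c2cc(-c3ccc(OC)cc3)ccc21` gives 4470 nM
- compound 2 `C=CCN1C(=O)C(=O)c2cc(-c3ccc(OC)cc3)ccc21` gives 7090 nM
- compound 3 `COc1ccc(-c2ccc3c(c2)C(=O)C(=O)N3Cc2cccc(Cl)c2)cc1` gives 320 nM

In a functional assay on HepG2 cells (Homo sapiens) for antiproliferative activity, read by MTT assay, with a stated time of 48 h (a lower number here means a stronger inhibitor, a higher number a weaker inhibitor), compound 3 has the lowest number of the three (320 nM). Two large steps lead there, a 14-fold lower number from compound 1 to compound 3 (1.15 log units; beyond the scatter) and a 22-fold lower number from compound 2 to compound 3 (1.35 log units; beyond the scatter), whereas a 1.6-fold higher number from compound 1 to compound 2 (0.20 log units; within the scatter) stays within the scatter. Compound 4 `COc1ccc(-c2ccc3c(c2)C(=O)C(=O)N3Cc2cccc(OC)c2)cc1` follows through (methoxy in place of chloro on an aromatic carbon), with methoxy in place of chloro on an aromatic carbon. Within the data shown here, no measured step tests this exchange. The aromatic ring brought in by a 14-fold lower number from compound 1 to compound 3 (1.15 log units; beyond the scatter) remains, so only a small rise is expected in this assay. The expected change is a 1.6-fold higher number from compound 3 to compound 4 (0.19 log units; within the scatter). For compound 4 the estimate is 500 nM (170 nM to 1500 nM).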

Compound 4, half-maximal inhibitory concentration: 700 nM
Compound 4: middle estimate off by 1.4-fold (0.15 log units), on the low side; the range from low to high includes it.
By their numbers in this assay, from the lowest: compound 3; then compound 4; then compounds 1 and 2 (each within the scatter of the next).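

In this assay, the group on this aromatic carbon does affect the result: there is a 2.2-fold higher number from compound 3 to compound 4 (0.34 log units; beyond the scatter) on going from chloro to methoxy. The benefit of the ring on the chain survives this exchange, with a 10-fold lower number from compound 2 to compound 4 (1.01 log units; beyond the scatter) and a 6.4-fold lower number from compound 1 to compound 4 (0.81 log units; beyond the scatter) still standing, so it does not require chloro. Nothing available explains the difference between chloro and methoxy at this position.

The compounds shown leave open whether a plain phenyl ring, with neither group, would do as well. On these data alone, how an amine or a carboxylic acid would read at this position also remains open.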